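The source may report more compounds than this note shows. Statements on the series, on what has been measured and on what is new or still open speak of the compounds shown alone.

Working notes on the series. Compound 1 `COc1cc2c(Oc3c(F)cc(NC(=O)NN4C(=O)CCSC4c4c(F)cccc4F)cc3F)ccnc2cc1OCCCN1CCCC1`, compound 2 `COc1cc2c(Oc3c(F)cc(NC(=O)NN4C(=O)CCSC4c4c(F)cccc4F)cc3F)ccnc2cc1OCCCN1CCc2sccc2C1` and compound 3 `COc1cc2c(Oc3c(F)cc(NC(=O)NN4C(=O)CCSC4c4c(F)cccc4F)cc3F)ccnc2cc1OCCCN1CCC(C)CC1` share one core and differ only in the amine on the saturated chain carbon, three bonds along the chain from an oxygen on an aromatic ring. In a functional assay on HT-29 cells (Homo sapiens) for antiproliferative activity, read by MTT assay, with a stated time of 72 h (on this read-out higher numbers stand for weaker inhibition and lower numbers for stronger inhibition), compound 1 gives 270 nM, compound 2 gives 1320 nM and compound 3 gives 410 nM. Compound 3 stands second highest of the three numbers: a 1.5-fold higher number from compound 1 to compound 3 (0.18 log units; within the scatter), while a 3.2-fold lower number from compound 2 to compound 3 (0.51 log units; beyond the scatter). Compound 4 `COc1cc2c(Oc3c(F)cc(NC(=O)NN4C(=O)CCSC4c4c(F)cccc4F)cc3F)ccnc2cc1OCCCN1C[C@H]2CCCC[C@H]2C1` carries a group of 9 heavy atoms (8 carbon, 1 nitrogen; one five-membered non-aromatic ring with 1 hetero atom, one six-membered non-aromatic ring of carbon only) in place of a group of 7 heavy atoms (6 carbon, 1 nitrogen; one six-membered non-aromatic ring with 1 hetero atom), on a saturated chain carbon, three bonds along the chain from an oxygen on an aromatic ring. Among the compounds with values here, one measured step bears directly on this: a 4.9-fold higher number from compound 1 to compound 2 (0.69 log units; beyond the scatter). The step from compound 2 to compound 3 already noted points the same way; in both the amine built from two rings gave the higher number, whereas the single-ring swap from compound 1 to compound 3 stayed within the scatter. For compound 4 a modest rise in the number is therefore expected, a 1.6-fold higher number from compound 3 to compound 4 (0.20 log units; within the scatter), estimated at 650 nM with a range of 250 nM to 1600 nM.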

Compound 4, half-maximal inhibitory concentration: 790 nM
The estimate for compound 4 lay 1.2-fold (0.08 log units) below the measured number, within the range that was stated.
By their numbers in this assay, from the lowest: compounds 1, 3, 4 and 2 (each within the scatter of the next, the first and the last beyond it).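

In this assay a second amine built from two rings, this one without sulfur or an aromatic ring, again separates from pyrrolidin-1-yl at this position: a 2.9-fold higher number from compound 1 to compound 4 (0.47 log units; beyond the scatter). The split between single-ring and two-ring amines is not clean, however: compound 4 goes against it, with a 1.9-fold higher number from compound 3 to compound 4 (0.28 log units; within the scatter). The presence or absence of sulfur and an aromatic ring in the two-ring amine also gives no separation here: a 1.7-fold lower number from compound 2 to compound 4 (0.22 log units; within the scatter).

On these data alone, whether morpholin-4-yl or open-chain dimethylamino would follow the same trend at this position remains open. Nothing available accounts for these steps.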